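A few compounds are considered here, and "the series" means these few. Any claim that something is new, unique, unknown or untested is made for them only; others in the source may bear on it.

Compound 1 `CC1(c2ccc(I)cc2)SCC(C(C)(C)C)CS1` and compound 2 `CC(C)(C)C1CS(=O)(=O)C(C)(c2ccc(C#N)cc2)S(=O)(=O)C1` have both been measured in a physicochemical assay for lipophilicity; a higher number here means a more lipophilic compound, a lower number a more polar compound. In this assay compound 1 gives 6.5, while compound 2 gives 0.351, the lowest of the two numbers and far beyond the usual scatter from compound 1. Compound 3 `CC(C)(C)C1CS(=O)(=O)C(C)(c2ccc(I)cc2)S(=O)(=O)C1` differs from compound 2 in one place: iodo in place of cyano on an aromatic carbon. Among the compounds with values here, no pair of measured compounds shows this exact step, so its size is not known here. A rise in this assay is nevertheless expected from compound 2 to compound 3, of about a number 1.65 log units higher from compound 2 to compound 3 (beyond the scatter). Compound 3 is thus estimated at 2, within a range from 1.3 to 2.7.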

Compound 3, partition coefficient: 1.95
The estimate for compound 3 lay 0.05 log units above the measured number, and the stated range covers the measured number.
By their numbers in this assay, from the lowest: compound 2; then compound 3; then compound 1.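

On the aromatic carbon para to a large group, the swap of cyano for iodo counts for a lot: in this assay the number moves a number 1.60 log units higher from compound 2 to compound 3 (beyond the scatter) while the rest of the molecule stays the same. One position alone therefore produces a large change here, although the swap replaces a nitrile with a single iodine atom. Nothing measured here accounts for the size of this step.

Where a methoxy group, an amine or a carboxylic acid at this position would fall remains open. So does whether the same swap gives a similar step on a different core.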